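This account rests on a few compounds, and the source may have more. Where it says the series, first, only, none or still open, it means among the compounds named here.

Compound 1 `COc1cc(N(Cc2ccccc2)C(=O)CSc2nc3ccccc3s2)cc(OC)c1OC` carries the shared core of this series, and in a functional assay on HCT-116 cells (Homo sapiens) for antiproliferative activity, read by MTT assay, with a stated time of 48 h (on this read-out lower numbers stand for stronger inhibition and higher numbers for weaker inhibition), compound 1 gives 54500 nM. Compound 2 `COc1ccc(CN(C(=O)CSc2nc3ccccc3s2)c2cc(OC)c(OC)c(OC)c2)cc1F` in this assay gives 1830 nM. Compound 3 `COc1cc(N(Cc2ccc(C)cc2)C(=O)CSc2nc3ccccc3s2)cc(OC)c1OC` in this assay returns only a limit of the assay, > 80000 nM, so no number stands for it, as recorded at the limit of > 80000 nM in this assay, at which 1 of the 3 values shown sits. Between the measured members, the swap of the group on the saturated chain carbon bound to the amide-type nitrogen gave a 30-fold lower number from compound 1 to compound 2 (1.47 log units; beyond the scatter), whereas the methyl gave an at least 1.4-fold higher number from compound 1 to compound 3 (0.16 log units; that floor lies within the scatter), and the return from the substituted ring to the methyl ring gave an at least 43-fold higher number from compound 2 to compound 3 (1.64 log units; beyond the scatter).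

Compound 4 `COc1ccc(CN(C(=O)CSc2nc3ccccc3s2)c2cc(OC)c(OC)c(OC)c2)cc1C(F)(F)F` is the next member awaiting measurement in this assay. It differs from compound 3 as follows: 4-methoxy-3-(trifluoromethyl)phenyl in place of 4-methylphenyl on a saturated chain carbon bound to an amide-type nitrogen. Within the data shown here, the steps that bear on this are the two that exchange the group at that same place, both of them large and both pointing toward a lower number whenever a 4-methoxy-bearing ring replaces a plain or methyl ring, as in compound 2. Because compound 3 sits at > 80000 nM, the size of the coming step can only be bounded from one side. Compound 4 is therefore expected to give about 5000 nM, within 1200 nM to 40000 nM. The expected change is an at least 16-fold lower number from compound 3 to compound 4 (1.20 log units; beyond the scatter).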

Compound 4, half-maximal inhibitory concentration: > 80000 nM
Compound 4: a limit, no number (the forecaster's own chance of this, stated with the estimate: 15%); middle value at least 16-fold (1.20 log units) from the limit.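

At the saturated chain carbon bound to an amide-type nitrogen, the gain seen with the 3-fluoro-4-methoxyphenyl group of compound 2 does not carry over to 4-methoxy-3-(trifluoromethyl)phenyl: trifluoromethyl in place of fluoro gives an at least 43-fold higher number from compound 2 to compound 4 (1.64 log units; beyond the scatter), so a 4-methoxy group on this ring does not by itself secure activity in this assay. Against the plain phenyl group, the change gives an at least 1.4-fold higher number from compound 1 to compound 4 (0.16 log units; that floor lies within the scatter), which does not separate the two compounds, and the step between compound 3 and compound 4 cannot be read, as both values are limits. Compound 4 therefore joins compound 3 at the limit of the assay, leaving compound 2 as the only member of the series with a clear gain at this position: the limit of > 80000 nM in this assay, at which 2 of the 4 values shown sit.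

The compounds shown leave open whether the activity of compound 2 depends on the fluoro, the methoxy or the two together, which a 4-methoxyphenyl group, or a chloro or nitrile in place of the fluoro, would help to separate. They also leave open how far the true values of compound 3 and compound 4 lie beyond the limit.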